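Removing the ethyl group from compound 2

A few compounds are considered here, and "the series" means these few. Any claim that something is new, unique, unknown or untested is made for them only; others in the source may bear on it.

Measured in a functional assay on MCF7 cells (Homo sapiens) for cytotoxicity, read by MTT assay, with a stated time of 72 h; a lower number here means a stronger inhibitor, a higher number a weaker inhibitor:
- compound 1 `CNC(=O)c1cc(Oc2ccc(NC(=O)c3cc(-c4ccc(C)cc4)ncn3)cc2)ccn1`: 34600 nM
- compound 2 `CCc1ccc(-c2cc(C(=O)Nc3ccc(Oc4ccnc(C(=O)NC)c4)cc3)ncn2)cc1`: 6350 nM
- compound 3 `CCc1ccc(-c2cc(C(=O)Nc3ccc(Oc4ccnc(C(=O)NC)c4)c(F)c3)ncn2)cc1`: 7630 nM

Compound 2 sits at the low end of these numbers at 6350 nM, and compound 3 stays level with it within the scatter: a 1.2-fold higher number from compound 2 to compound 3 (0.08 log units; within the scatter). The next analogue, compound 4 `CNC(=O)c1cc(Oc2ccc(NC(=O)c3cc(-c4ccccc4)ncn3)cc2)ccn1`, has hydrogen in place of ethyl on an aromatic carbon, 4-ethylphenyl to phenyl: hydrogen in place of ethyl on an aromatic carbon.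

Two measured steps are available, and they do not bear equally. The fluoro step is made at another place in the molecule and says little here. The more relevant one is the methyl in place of hydrogen on a saturated chain carbon bound to an aromatic carbon: a 5.4-fold lower number from compound 1 to compound 2 (0.74 log units; beyond the scatter). This shows that shortening the group at this same place moved the number up, beyond the scatter. Compound 4 loses the whole chain, so a rise of similar or somewhat larger size is expected in this assay. Going by the values given here, no measured compound shows the bare phenyl, so the size remains uncertain.

The expected change is a 4.7-fold higher number from compound 2 to compound 4 (0.67 log units; beyond the scatter). For compound 4 the estimated value is 30000 nM, with an expected range of 11000 nM to 80000 nM.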

Compound 4, half-maximal inhibitory concentration: 18200 nM
Estimate against measurement, compound 4: 1.6-fold (0.22 log units) above, and the stated range covers the measured number.
By their numbers in this assay, from the lowest: compounds 2 and 3 (each within the scatter of the next); then compounds 4 and 1 (each within the scatter of the next).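

In this assay, removing the ethyl group from the phenyl ring gives a 2.9-fold higher number from compound 2 to compound 4 (0.46 log units; beyond the scatter), so the lower number of compound 2 depends on the ethyl group at this position. The earlier compounds shown here could not show how a bare phenyl compares with the methyl analogue, and the new step reads a 1.9-fold lower number from compound 1 to compound 4 (0.28 log units; within the scatter), which places the hydrogen of compound 4 and the methyl of compound 1 level with each other. Among these three compounds, the number therefore does not move one carbon at a time: hydrogen and methyl cannot be told apart, and only ethyl stands clear of both, which is a reading limited to compounds 1, 2 and 4.

Going by these compounds, it remains open whether a longer chain such as propyl, or a branched group such as isopropyl or tert-butyl, would take the number lower than ethyl does, and whether a chain is needed at all or a methoxy group or an amine at this place would serve equally well. Nothing on hand explains why ethyl separates from methyl and hydrogen in this way.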